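Isopropyl for methyl on the ethyl ester

A few compounds are considered here, and "the series" means these few. Any claim that something is new, unique, unknown or untested is made for them only; others in the source may bear on it.

Compound 3 (`CCOC(=O)CSc1nc(O)c(C)c(Cc2cccc3ccccc23)n1`) gives >= 287000 nM in a functional assay on MT4 cells (Homo sapiens) for cytotoxicity (a higher number here means that more compound is tolerated, a lower number that less compound is tolerated), and this is a limit and not a number. Compound 2 (`COC(=O)CSc1nc(O)c(C)c(Cc2cccc3ccccc23)n1`) gives >= 296000 nM in this assay and this is also a limit. Compound 1 (`Cc1c(O)nc(SCC(=O)c2ccc(Cl)cc2)nc1Cc1cccc2ccccc12`) gives >= 198000 nM in this assay and this too is a limit. Compound 3 therefore has no numerical value, and neither of the other two compounds offers one for comparison.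

The next change leads to compound 4 (`CCOC(=O)CSc1nc(O)c(C(C)C)c(Cc2cccc3ccccc23)n1`), with isopropyl in place of methyl on an aromatic carbon ortho to a hydroxy group. The measurements contain a step that the two limits leave unreadable from compound 1 to compound 2 and also a step that the two limits leave unreadable from compound 1 to compound 3 and also a step that the two limits leave unreadable from compound 2 to compound 3 but none of these changes the group on the aromatic carbon. They give no size to carry over, and the expectation rests only on the limits of the three compounds. No step beyond the scatter is expected, and a further limit is the most likely report. Within the data shown here, the expected size is an at least 1.3-fold lower number from compound 3 to compound 4 (0.11 log units; that floor lies within the scatter) as an estimate with no measured step of this kind behind it. In this assay compound 4 is expected at 220000 nM with an estimated range from 60000 nM to 300000 nM as its span.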

Compound 4, half-maximal cytotoxic concentration: 175000 nM
For compound 4 the middle estimate is 1.3-fold (0.10 log units) above the measured one, and the stated range covers the measured number.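

Isopropyl in place of methyl on an aromatic carbon, ortho to a hydroxy group, gives the first step in the series that can be read at all in this assay: an at least 1.6-fold lower number from compound 3 to compound 4 (0.21 log units; that floor lies within the scatter). Only a floor can be given for this step, and its true size stays unknown, because compound 3 carries a limit and not a number: the limit of >= 287000 nM in this assay, at which 1 of the 4 values shown sits. The steps among compound 1, compound 2 and compound 3 cannot be read, so this aromatic carbon is the only place shown where a change yields a direction, though the floor alone does not take that direction beyond the scatter.

As far as these compounds go, whether the fall in tolerated concentration follows the size of the group on this carbon remains open, since ethyl, cyclopropyl or tert-butyl here would be needed to separate a gradual trend from an effect specific to isopropyl. Also open, from the compounds shown here alone, is whether isopropyl on this carbon gives a comparable step when the ethyl ester is replaced by the methyl ester of compound 2 or the 4-chlorophenyl ketone of compound 1.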